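From cyclohexylamino to 4-methylpiperazin-1-yl on a carbonyl carbon

A few compounds are considered here, and "the series" means these few. Any claim that something is new, unique, unknown or untested is made for them only; others in the source may bear on it.

Measured in a functional assay on the whole organism with Mus musculus as the target; a lower number here means that less compound is needed, a higher number that more compound is needed for the effect:
Compound 1 `CCC(C)NC(=O)CCC(=O)c1cccc(C(F)(F)F)c1`: > 200 mg/kg
Compound 2 `O=C(CCC(=O)c1cccc(C(F)(F)F)c1)NC1CCCCC1`: > 200 mg/kg

Both entries are limits of the assay, not numbers. Compound 2 therefore stands only at a limit, > 200 mg/kg. For the measured compounds named here, the single measured step gives no usable size: a step that the two limits leave unreadable from compound 1 to compound 2. What the series offers is the limit of > 200 mg/kg in this assay, at which 2 of the 2 values shown sit.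

Compound 3 `CN1CCN(C(=O)CCC(=O)c2cccc(C(F)(F)F)c2)CC1` has not yet been measured. It replaces the cyclohexylamino group of compound 2 with 4-methylpiperazin-1-yl on a carbonyl carbon: 4-methylpiperazin-1-yl in place of cyclohexylamino on a carbonyl carbon. No readable step bears on this change, so no direction can be drawn from the data in this assay, and a further limit is the likeliest expected outcome. The expected step is a step that the limit leaves unreadable from compound 2 to compound 3. For compound 3 the estimate is 220 mg/kg, with an expected range from 100 mg/kg to 450 mg/kg.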

Compound 3, dose for half-maximal effect: > 50 mg/kg
Compound 3 was reported as a limit; the forecaster's own chance of this, stated with the estimate: 70%; the middle value does not contradict the limit.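

Compound 3, like compound 1 and compound 2, is reported only as a limit, so no step among these three compounds can be read. The compounds shown leave open whether 4-methylpiperazin-1-yl in place of cyclohexylamino changes the dose needed, and in which direction.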